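The source may report more compounds than this note shows. Statements on the series, on what has been measured and on what is new or still open speak of the compounds shown alone.

Compound 1 `COc1cc(/C(=C/c2ccccc2)C(C)O)cc(OC)c1OC`: > 100000 nM
Compound 2 `COc1cc(/C(=C/c2ccc(Cl)cc2)C(C)O)cc(OC)c1OC`: > 100000 nM

Both results come from a functional assay on B16 cells (Mus musculus) for antiproliferative activity, read by MTT assay, with a stated time of 72 h (on this read-out lower numbers stand for stronger inhibition and higher numbers for weaker inhibition), and neither is a number. For compound 1 the result > 100000 nM is a limit of the assay. Going by these compounds, for compound 2 the result > 100000 nM is also a limit, so its true position is unknown. The two compounds share this outcome: the limit of > 100000 nM in this assay, at which 2 of the 2 values shown sit.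

Compound 3 `COc1cc(/C(=C/c2ccc(Br)cc2)C(C)O)cc(OC)c1OC` differs from compound 2 in one place: bromo in place of chloro on an aromatic carbon. This puts bromo in place of chloro on an aromatic carbon, turning 4-chlorophenyl into 4-bromophenyl.

Among the measured compounds shown here, only one measured step bears on this change, the replacement of hydrogen by chloro, and it is a step that the two limits leave unreadable from compound 1 to compound 2. It therefore offers no size to carry over. With no readable effect of either halogen, no step beyond the usual scatter is expected in this assay, in either direction. The expectation rests on compound 2, whose result > 100000 nM is a limit. The expected step is a number no higher from compound 2 to compound 3 (the limit leaves the size open). For compound 3 the estimated value is 100000 nM, with an expected range from 30000 nM to 200000 nM.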

Compound 3, half-maximal inhibitory concentration: > 100000 nM
Compound 3 gave a limit, no number; the forecaster's own chance of this, stated with the estimate: 80%; the middle value lies on the limit itself.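

In this assay compound 3 gives > 100000 nM, which is a limit and not a number. The steps among compound 1, compound 2 and compound 3 therefore cannot be read, and the three share one outcome: the limit of > 100000 nM in this assay, at which 3 of the 3 values shown sit.

The compounds shown leave open whether hydrogen, chloro or bromo on this aromatic carbon changes the antiproliferative activity at all.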